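Replacing the 1-methylethenyl group of compound 2

The compounds below may be only part of what the source reports. "The series", "measured", "known", "first", "only" and "open" are said of these compounds alone.

Compound 1 `C=C(C)c1cccc(C(C)(C)NC(=O)Nc2ccc(Cl)c(C(N)=O)c2)c1` gives > 2 h (a limit)
Compound 2 `C=C(C)c1cccc(C(C)(C)NC(=O)Nc2ccc3cccnc3c2)c1` gives > 2 h (a limit)

In an ADME assay on a cell-free system (plasma, Mus musculus) for metabolic stability (on this read-out lower numbers stand for a shorter-lived compound and higher numbers for a longer-lived compound), compound 2 gives > 2 h as a limit of the assay and not a number. Compound 3 `C/C(=N\O)c1cccc(C(C)(C)NC(=O)Nc2ccc3cccnc3c2)c1` differs from compound 2 on an aromatic carbon, where a group of 4 heavy atoms replaces the 1-methylethenyl group a group of 4 heavy atoms (2 carbon, 1 nitrogen, 1 oxygen; no ring) in place of a group of 3 heavy atoms (3 carbon; no ring), on an aromatic carbon and the rest stays the same. Among the measured compounds shown here, no measured step gives the size of this change, so none beyond the scatter is expected in this assay here. The estimated step that the limit leaves unreadable from compound 2 to compound 3 is expected to stay small. Compound 3 is expected at 3 h with an estimated range from 1.5 h to 6 h for now.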

Compound 3, half-life: > 2 h
Compound 3 gave a limit, no number (the forecaster's own chance of this, stated with the estimate: 75%); the middle value is on the limit's open side.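

Among the compounds shown here, compound 3, like compound 2, gives only a limit in this assay and not a number, so no step between the two can be read. The compounds shown leave open how long each one actually lasts and whether replacing the 1-methylethenyl group changes that at all: the limit of > 2 h in this assay, at which 3 of the 3 values shown sit.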